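Cyano Added to Compound 2: Expected Cytotoxicity

The source may report more compounds than this note shows. Statements on the series, on what has been measured and on what is new or still open speak of the compounds shown alone.

Of the compounds shown here, two that share one core have been measured in an ADME assay on Huh-7 cells (Homo sapiens) for cytotoxicity; on this read-out higher numbers stand for weaker inhibition and lower numbers for stronger inhibition. Compound 1 `CN(c1cc2ncc(=O)[nH]c2cc1NC(=N)NCc1ccccc1)C1CCCCC1` gives 9940 nM in this assay. Compound 2 `CN(c1cc2ncc(=O)[nH]c2cc1Nc1nc(-c2ccccc2)cs1)C1CCCCC1` gives 62500 nM in this assay, the highest of the two numbers; its nearest neighbour is compound 1, whose number is lower by a margin beyond the usual scatter, so compound 2 is the weaker inhibitor of these liver-derived cells.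

Compound 3 `CN(c1cc2ncc(=O)[nH]c2cc1Nc1nc(-c2ccc(C#N)cc2)cs1)C1CCCCC1` has not yet been measured. It differs from compound 2 in a single place: cyano in place of hydrogen on an aromatic carbon. Among the measured compounds no pair differs by just this change, so there is no measured step that shows what a cyano group in this position does to the read-out. A change this small, adding one small group at the edge of the molecule, is expected to shift the number only modestly, and the direction cannot be read from the two values at hand. The step from compound 2 to compound 3 is therefore expected to be a 1.3-fold lower number from compound 2 to compound 3 (0.10 log units; within the scatter), within or near the scatter. Compound 3 is expected to give 50000 nM in this assay, with a range from 18000 nM to 140000 nM.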

Compound 3, half-maximal inhibitory concentration: 18100 nM
The estimate for compound 3 lay 2.8-fold (0.44 log units) above the measured number, within the range that was stated.
By their numbers in this assay, from the lowest: compounds 1 and 3 (each within the scatter of the next); then compound 2.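

Replacing phenyl with 4-cyanophenyl in this assay gives a 3.5-fold lower number from compound 2 to compound 3 (0.54 log units; beyond the scatter) and provides the first direct measure of a change at this position, on a six-membered aromatic ring of carbon only and para to a large group. It shows that the position is not silent: adding a cyano group of only 2 heavy atoms moves the number beyond the usual scatter, and the lower number means stronger inhibition of these cells. Nothing available here explains why the number falls, so this single step records an effect without revealing its cause.

The compounds shown leave open whether the effect is specific to cyano or whether another group at the same place, such as an amine, a carboxylic acid or a longer chain, would move the number in the same direction and by a similar amount. They also leave open whether a cyano group placed elsewhere on this ring, or the same change made on a different scaffold, would produce a comparable step.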